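Ester in place of primary amide on the propenoyl chain

The compounds below may be only part of what the source reports. "The series", "measured", "known", "first", "only" and "open" are said of these compounds alone.

The series pairs an acrylic acid derivative with a pyridine bearing a bicyclic aryl group; compound 1 `CCOC(=O)/C=C/c1ccncc1-c1ccc2[nH]ccc2c1`, compound 2 `NC(=O)/C=C/c1ccncc1-c1ccc2ccccc2c1` and compound 3 `CNC(=O)/C=C/c1ccncc1-c1ccc2[nH]ccc2c1` have been measured. In a functional assay on MDA-MB-231 cells (Homo sapiens) for inhibition, read by sulforhodamine B assay, with a stated time of 72 h (a higher number here means a weaker inhibitor of growth, a lower number a stronger inhibitor of growth), compound 1 gives > 10000 nM, which is a limit of the assay and not a number. In this assay compound 3 gives > 10000 nM, again a limit. Consequently the single step within the measured set, a step that the two limits leave unreadable from compound 1 to compound 3, cannot be sized.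

Compound 2 stands at the same place. In this assay compound 2 gives > 10000 nM, a limit of the assay rather than a number. Going by the values given here, all measured values sit together, as stated by the limit of > 10000 nM in this assay, at which 3 of the 3 values shown sit, so no measured step gives a direction or a size.

Compound 4 `COC(=O)/C=C/c1ccncc1-c1ccc2ccccc2c1` is not yet measured. It differs from compound 2 by methoxy in place of amino on a carbonyl carbon. Among the compounds with values here, the only comparable change, from compound 1 to compound 3, is unreadable, so no step size is transferable, and the expectation is that compound 4 stays at or near the limit in this assay.

The estimate for compound 4 in this assay is 20000 nM, ranging from 5000 nM to 100000 nM. The step this estimate implies, a step that the limit leaves unreadable from compound 2 to compound 4, is expected to be none beyond the scatter.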

Compound 4, concentration for 50% growth inhibition: 4710 nM
Compound 4: middle estimate off by 4.2-fold (0.63 log units), on the high side; the whole stated range lies above it.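

Methoxy in place of amino on a carbonyl carbon gives, in this assay, an at least 2.1-fold lower number from compound 2 to compound 4 (0.32 log units; beyond the scatter), the first step in the series with a readable direction. Where the earlier compounds gave only limits, this pair shows that the group on this carbonyl carbon can move the read-out on the core of compound 2, with methoxy giving the stronger inhibitor of growth of the two. The size of the step remains a lower bound, because compound 2 carries only a limit and most of the series sits at that same limit: the limit of > 10000 nM in this assay, at which 3 of the 4 values shown sit.

Going by these compounds, the step from compound 1 to compound 3 cannot be read, so it remains open whether the group on this carbonyl carbon matters on the core of compound 1 as well. On these data alone, it also remains open how far the read-out moves with other groups on the same carbonyl carbon, such as a hydroxyl as in the carboxylic acid, or a longer chain such as propoxy or butoxy.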